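A few compounds are considered here, and "the series" means these few. Any claim that something is new, unique, unknown or untested is made for them only; others in the source may bear on it.

Measured so far:
compound 1 `C/C(=C\CC/C(C)=C/CC[C@@H]1[C@@]2(C)CCC(=O)C(C)(C)[C@H]2CC[C@@]1(C)O)CC/C=C(\C)C(=O)OCc1cn(-c2ccccc2Br)nn1` — > 150000 nM
compound 2 `C/C(=C\CC/C(C)=C/CC[C@@H]1[C@@]2(C)CCC(=O)C(C)(C)[C@H]2CC[C@@]1(C)O)CC/C=C(\C)C(=O)OCc1cn(-c2cccc(Br)c2)nn1` — > 150000 nM

In a functional assay on DU-145 cells (Homo sapiens) for antiproliferative activity, read by MTT assay, with a stated time of 48 h (a higher number here means a weaker inhibitor, a lower number a stronger inhibitor), compound 1 gives only a limit, > 150000 nM. In this assay compound 2 likewise gives only a limit, > 150000 nM. The step that the two limits leave unreadable from compound 1 to compound 2 is therefore not readable. Compound 3 `C/C(=C\CC/C(C)=C/CC[C@@H]1[C@@]2(C)CCC(=O)C(C)(C)[C@H]2CC[C@@]1(C)O)CC/C=C(\C)C(=O)OCc1cn(-c2ccccc2Cl)nn1` differs from compound 1 by chloro in place of bromo on an aromatic carbon. Among the measured compounds shown here, the single measured step concerns another place and has no size; the only pointer is the limit of > 150000 nM in this assay, at which 2 of the 2 values shown sit. For compound 3 no step beyond the scatter in this assay is expected, so a step that the limit leaves unreadable from compound 1 to compound 3 is the working estimate. Compound 3 is expected at 200000 nM, within 100000 nM to 400000 nM, quite possibly reported again only as a limit.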

Compound 3, half-maximal inhibitory concentration: > 150000 nM
Compound 3 gave a limit, no number; the forecaster's own chance of this, stated with the estimate: 85%; the middle value does not contradict the limit.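

Among the compounds shown here, compound 3 gives only a limit in this assay, > 150000 nM, so no step between it and compound 1 or compound 2 can be read. The compounds shown leave open whether chloro in place of bromo changes activity at all, since none has yielded a number: the limit of > 150000 nM in this assay, at which 3 of the 3 values shown sit.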